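A few compounds are considered here, and "the series" means these few. Any claim that something is new, unique, unknown or untested is made for them only; others in the source may bear on it.

Measured so far:
compound 1, `COc1ccc(OC)c(Sc2ccc3nnc(-c4ccccc4)n3n2)c1`: 173 nM
compound 2, `COc1ccc(OC)c(Sc2ccc3nnc(-c4cn(C)nc4C)n3n2)c1`: 323 nM

In an assay on isolated protein for inhibition of Leucine-rich repeat serine/threonine-protein kinase 2 (Homo sapiens), in the presence of a further agent that is not named here (a lower number here means a stronger inhibitor, a higher number a weaker inhibitor), compound 1 gives 173 nM, the lowest of the two numbers shown. Going by the values given here, the only measured step, a 1.9-fold higher number from compound 1 to compound 2 (0.27 log units; within the scatter), changes the group on the shared core and stays within the scatter. Compound 3, `COc1ccccc1Sc1ccc2nnc(-c3ccccc3)n2n1`, differs from compound 1 by hydrogen in place of methoxy on an aromatic carbon. Among the compounds with values here, no measured step touches this place, so nothing here tells how removing the methoxy matters. The expected step is therefore small: a 1.4-fold higher number from compound 1 to compound 3 (0.16 log units; within the scatter), within the scatter. Compound 3 is estimated at 250 nM in this assay, in a range from 100 nM to 700 nM.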

Compound 3, half-maximal inhibitory concentration: 1070 nM
Compound 3: middle estimate off by 4.3-fold (0.63 log units), on the low side; measured number outside the range, above it.
By their numbers in this assay, from the lowest: compounds 1 and 2 (each within the scatter of the next); then compound 3.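

In this assay, going by these compounds alone, putting hydrogen in place of this methoxy gives a 6.2-fold higher number from compound 1 to compound 3 (0.79 log units; beyond the scatter) while the only earlier step, at another place on the shared core, stayed within the scatter. Within the data shown here, this methoxy, meta to a large group and para to a methoxy group, therefore matters to the number in a way the earlier compounds could not show. No measurement at hand explains the rise. Still open, going by these compounds, is whether another group here, such as ethoxy, a fluorine atom or an amine, would match methoxy, and whether the remaining methoxy group matters as much.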